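The source may hold more compounds than are shown below. What is called first, only, known or untested is meant among the compounds shown, and "the series" means these compounds.

Compound 2 `COc1cc2c(Oc3ccc(NC(=O)c4nn(-c5ccccc5C(F)(F)F)c(=O)cc4C)cc3F)ccnc2cc1OCCCN1CCN(C)CC1` was tested in a functional assay on NCI-H460 cells (Homo sapiens) for inhibition, read by MTT assay, with a stated time of 72 h (a lower number here means a stronger inhibitor, a higher number a weaker inhibitor), where compound 2 gives 240 nM. Among the compounds with values here, only one other measured compound stands beside it: compound 1 `COc1cc2c(Oc3ccc(NC(=O)c4nn(-c5ccccc5C(F)(F)F)c(=O)cc4C)cc3F)ccnc2cc1OCCCN1CCC(C)CC1`, which in this assay gives 200 nM. Within the data shown here, the single measured step, a 1.2-fold higher number from compound 1 to compound 2 (0.08 log units; within the scatter), changes only the amine at the end of the chain, and compound 2 stands alongside compound 1 with the two numbers lying within the scatter of each other. Compound 3 `COc1cc2c(Oc3ccc(NC(=O)c4nn(-c5cccc(F)c5)c(=O)cc4C)cc3F)ccnc2cc1OCCCN1CCN(C)CC1` has not yet been measured. It differs from compound 2 in one place: 3-fluorophenyl in place of 2-(trifluoromethyl)phenyl on an aromatic nitrogen. No measured step touches the group on the aromatic nitrogen, so nothing in the data says how large a move to expect or in which direction; the one thing shown is that a change at the far chain end left the number nearly unchanged. The expected step is a 1.3-fold higher number from compound 2 to compound 3 (0.10 log units; within the scatter). Compound 3 is therefore estimated at 300 nM, with a range from 90 nM to 1000 nM.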

Compound 3, half-maximal inhibitory concentration: 260 nM
Compound 3: middle estimate off by 1.2-fold (0.06 log units), on the high side; low and high end bracket the measured number.
By their numbers in this assay, from the lowest: compounds 1, 2 and 3 (each within the scatter of the next).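

In this assay, within the data shown here, the replacement on the aromatic nitrogen gives a 1.1-fold higher number from compound 2 to compound 3 (0.03 log units; within the scatter), the first reading at this position, where the earlier step changed only the amine at the chain end. The swap alters both the substituent and where it sits on the phenyl ring, going from 10 heavy atoms in 2-(trifluoromethyl)phenyl to 7 in 3-fluorophenyl, yet the two numbers remain within the scatter, so this position accepts at least these two substituted phenyl groups. No measurement here explains why the two compounds read alike.

With both features altered together, their separate contributions cannot be told apart. A plain phenyl or 2-fluorophenyl would help to separate them, while a non-aromatic group such as cyclohexyl or ethyl on that nitrogen would test whether an aryl ring is needed at all.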